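The source may report more compounds than this note shows. Statements on the series, on what has been measured and on what is new or still open speak of the compounds shown alone.

Compound 1 `Cc1cccc(Nc2ncnc3ccc(NC(=S)NCc4ccccc4)cc23)c1C` in a functional assay on MDA-MB-231 cells (Homo sapiens) for inhibition, read by MTT assay, with a stated time of 48 h (a lower number here means a stronger inhibitor of growth, a higher number a weaker inhibitor of growth), gives 28700 nM. Compound 2 `S=C(Nc1ccccc1)Nc1ccc2ncnc(Nc3cccc(Br)c3)c2c1` gives 10000 nM.

Of these two numbers, compound 2 has the lower one, and compound 1 stands at a higher value, a gap beyond the usual scatter of the assay. Compound 3 `S=C(Nc1ccc(Cl)c(Cl)c1)Nc1ccc2ncnc(Nc3cccc(Br)c3)c2c1` differs from compound 2 in one place: 3,4-dichlorophenyl in place of phenyl on an amide-type nitrogen. Among the measured compounds shown here, no measured pair shows what this change does, so the expectation rests on compound 2 alone. Compound 3 is expected to remain close to compound 2, and the step of a 1.7-fold lower number from compound 2 to compound 3 (0.22 log units; within the scatter) is expected to be small, possibly toward a lower number, or none beyond the scatter. Compound 3 is estimated at 6000 nM, with a range of 2000 nM to 20000 nM.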

Compound 3, concentration for 50% growth inhibition: 4800 nM
Compound 3: the middle estimate sits 1.3-fold (0.10 log units) above what was measured; the range from low to high includes it.
By their numbers in this assay, from the lowest: compound 3; then compound 2; then compound 1.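

In this assay, among the compounds shown here, 3,4-dichlorophenyl in place of phenyl on an amide-type nitrogen gives a 2.1-fold lower number from compound 2 to compound 3 (0.32 log units; beyond the scatter) and is the first measured change at this position. It shows that this place takes the larger 3,4-dichlorophenyl group with a modest gain in growth inhibition rather than a loss. Nothing measured here gives a reason for the step. As far as these compounds go, whether 3-chlorophenyl or 4-chlorophenyl alone would give a similar step remains open. So does the outcome for a phenyl carrying a methoxy group, an amine or a carboxylic acid at this place.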